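The source may report more compounds than this note shows. Statements on the series, on what has been measured and on what is new or still open speak of the compounds shown alone.

Series notes, step from compound 2 to compound 3.

Of the compounds shown here, two have been measured in an assay on Huh-7 cells for agonist activity at Bile acid receptor (Homo sapiens), read by a luciferase reporter; on this read-out lower numbers stand for an effect already at smaller amounts and higher numbers for an effect only at larger amounts of compound. Compound 1 `CC(C)c1onc(-c2c(Cl)cccc2Cl)c1COc1ccc(-c2nc3ccc(C(=O)O)cc3n2C2CC2)cc1` gives 16.5 nM. Compound 2 `CC(C)c1onc(-c2c(Cl)cccc2Cl)c1COc1ccc(-c2nc3ccc(C(=O)O)cc3n2-c2ccc(F)cc2)cc1` gives 32.2 nM. Going by the values given here, the only single-point change measured so far, a 2.0-fold higher number from compound 1 to compound 2 (0.29 log units; within the scatter), exchanged an alkyl ring for an aryl group on the ring nitrogen of the shared core. On the numbers shown, compound 2 has the higher of the two values, and its only neighbour, compound 1, lies within the scatter of it.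

Compound 3 `CC(C)Cn1c(-c2ccc(OCc3c(-c4c(Cl)cccc4Cl)noc3C(C)C)cc2)nc2ccc(C(=O)O)cc21` is not yet measured. Its difference from compound 2 is isobutyl in place of 4-fluorophenyl on an aromatic nitrogen. Among the compounds with values here, the one measured step that bears on this position, a 2.0-fold higher number from compound 1 to compound 2 (0.29 log units; within the scatter), shows that moving between a small alkyl group and an aryl group there is within the scatter, so no step beyond the scatter is expected in this assay for the return to an alkyl group, a 1.5-fold lower number from compound 2 to compound 3 (0.17 log units; within the scatter). Compound 3 is therefore estimated at 22 nM, with a range from 8 nM to 60 nM.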

Compound 3, half-maximal effective concentration: 5.26 nM
Estimate against measurement, compound 3: 4.2-fold (0.62 log units) above; the whole stated range lies above it.
By their numbers in this assay, from the lowest: compound 3; then compounds 1 and 2 (each within the scatter of the next).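

In this assay the group on the aromatic nitrogen now moves the number beyond the scatter: isobutyl in place of 4-fluorophenyl gives a 6.1-fold lower number from compound 2 to compound 3 (0.79 log units; beyond the scatter) and isobutyl in place of cyclopropyl gives a 3.1-fold lower number from compound 1 to compound 3 (0.50 log units; beyond the scatter) while the earlier exchange of cyclopropyl for 4-fluorophenyl stayed within the scatter. Going by these compounds alone, the position is therefore not indifferent to its substituent, and among the three compounds the only group with no ring, in compound 3, gives the lowest number, with both ring-bearing groups on the higher side. That link rests on a single open-chain example, and no measurement is available that accounts for the size of either step.

Going by these compounds, it remains open whether the lower number belongs to isobutyl specifically or would also hold for a straight butyl chain, a longer chain such as pentyl, or a smaller ethyl group. Equally open, on these data alone, is how this position would respond to an open chain ending in a hydroxyl group or an amine, and whether either step carries over to any read-out other than this reporter assay.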